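From 2-oxopiperidin-1-yl to acetamido on a shared core

The source may report more compounds than this note shows. Statements on the series, on what has been measured and on what is new or still open speak of the compounds shown alone.

For the measured compounds named here, only one number anchors this short series. In an ADME assay on the whole organism (plasma) for pharmacokinetics, with Rattus norvegicus as the target, at a dose of 3 mg/kg by the oral route (a higher number here means more compound in the circulation at the dose given, a lower number less compound in the circulation), compound 1 (`Cc1ccc(-c2cc(Cl)ccc2OCc2ccc(F)cc2F)n1-c1cc(C(=O)O)ccc1F`) gives 66700000 ng.h/mL as its measured result. In this assay compound 2 (`Cc1ccc(-c2cc(Br)ccc2OCc2ccc(F)cc2F)n1-c1cc(C(=O)O)cc(N2CCCCC2=O)c1`) stands at "not determined" (no result reported) and so offers no single number to start from. Compound 3 (`CC(=O)Nc1cc(C(=O)O)cc(-n2c(C)ccc2-c2cc(Br)ccc2OCc2ccc(F)cc2F)c1`) differs from compound 2 by one change, acetamido in place of 2-oxopiperidin-1-yl on an aromatic carbon. Going by the values given here, no measured pair shows what such a swap does, and compound 2 has no value against which to size a step. No step beyond the scatter is expected in this assay in either direction, so the expectation falls back on compound 1 at 66700000 ng.h/mL as the only measured relative. Compound 3 is estimated at 30000000 ng.h/mL with an expected range from 6000000 ng.h/mL to 120000000 ng.h/mL in this read-out.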

Compound 3, area under the concentration-time curve: 350000000 ng.h/mL
The estimate for compound 3 lay 12-fold (1.07 log units) below the measured number; the whole stated range lies below it.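

In this assay, for the compounds shown here, compound 3 gives 350000000 ng.h/mL, but compound 2 has no single number there, so no step between them can be read. As far as these compounds go, what acetamido in place of 2-oxopiperidin-1-yl does to this read-out stays open. Nothing shown explains the result of compound 3.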